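The source may hold more compounds than are shown below. What is called first, only, known or untested is meant among the compounds shown, and "the series" means these compounds.

Measured so far:
compound 1, `CCCN(CC(=O)N(C)C)c1nc(C)nc2c1c(C)nn2-c1ccc(OC)cc1C`: 1410 nM
compound 2, `CCCNCc1noc(Nc2nc(C)nc3c2c(C)nn3-c2ccc(OC)cc2C)n1`: 84 nM

Both were tested in a functional assay on CHO cells for antagonist activity at corticotropin-releasing factor receptor 1 (Homo sapiens), read by cAMP accumulation; on this read-out lower numbers stand for stronger inhibition and higher numbers for weaker inhibition. Of the two numbers, compound 1 stands highest, so it is the weaker of the pair, and the gap to compound 2 is beyond the usual scatter of this assay. Compound 2 differs from compound 1 in more than one place, so nothing can be said about which part of that change matters.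

Compound 3, `CC[C@H](COC)Nc1nc(C)nc2c1c(C)nn2-c1ccc(OC)cc1C`, has not yet been measured. It differs from compound 1 in a single place: (1-(methoxymethyl)propyl)amino in place of ((dimethylcarbamoyl)methyl)(propyl)amino on an aromatic carbon. Going by the values given here, no pair of measured compounds shows this exact change, so the size of the step cannot be read off from the data. Among the compounds with values here, with no measured step to anchor it, the change is nonetheless expected to move the number downward, beyond the scatter, by a step of a 35-fold lower number from compound 1 to compound 3 (1.55 log units; beyond the scatter). That places compound 3 somewhere between the two measured values. The estimate for compound 3 in this assay is 40 nM, with a range from 6 nM to 300 nM.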

Compound 3, inhibition constant: 210 nM
The estimate for compound 3 lay 5.3-fold (0.72 log units) below the measured number, and the stated range covers the measured number.
By their numbers in this assay, from the lowest: compound 2; then compound 3; then compound 1.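

Going by these compounds alone, the first single-place change at this position shows that the group on this aromatic carbon, next to the ring nitrogen, clearly affects the result in this assay: replacing ((dimethylcarbamoyl)methyl)(propyl)amino with (1-(methoxymethyl)propyl)amino gives a modest gain (a 6.7-fold lower number from compound 1 to compound 3 (0.83 log units; beyond the scatter)), and the smaller entering group adds a hydrogen-bond donor and a defined stereocentre. With the ring-bound nitrogen kept, the substituent on that nitrogen also matters, since 1-(methoxymethyl)propyl in place of 3-((propylamino)methyl)-1,2,4-oxadiazol-5-yl gives a modest loss (a 2.5-fold higher number from compound 2 to compound 3 (0.40 log units; beyond the scatter)), so the oxadiazole-bearing group remains the better of these two. No supporting measurement explains either step.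

The change from compound 1 to compound 3 replaces the whole group at once, so these numbers cannot separate the contributions of the added donor, the lost carbonyl and the shorter group. From the compounds shown here alone, it also remains open how a hydroxymethyl or ethoxymethyl arm in place of methoxymethyl, or the opposite configuration at the stereocentre, would fare in this assay.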